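A few compounds are considered here, and "the series" means these few. Any claim that something is new, unique, unknown or untested is made for them only; others in the source may bear on it.

Working notes on the series. Compound 1, `CCCN(CCC)c1cc(C)nc2c(-c3ncc(C(F)(F)F)cc3Cl)c(C)nn12`, gives 1.2 nM in an assay on isolated protein for binding affinity to corticotropin-releasing factor receptor 1 (Homo sapiens); on this read-out higher numbers stand for weaker inhibition and lower numbers for stronger inhibition. Compound 2, `CCCN(CCC)c1cc(C)nc2c(-c3ncc(C)cc3[N+](=O)[O-])c(C)nn12`, gives 14 nM in this assay. On the two numbers in hand, compound 2 stands highest; its nearest neighbour is compound 1, whose number is lower by a margin beyond the usual scatter, so compound 2 is the weaker of the pair on this read-out.

Compound 3, `CCCN(CCC)c1cc(C)nc2c(-c3ncc(C)cc3OC)c(C)nn12`, has not yet been measured in this assay. It differs from compound 2 in one place: methoxy in place of nitro on an aromatic carbon. The methoxy that enters sits on an aromatic carbon of a six-membered aromatic ring with one nitrogen, ortho to a large group, two atoms from the ring nitrogen and meta to a methyl group. For the measured compounds named here, no measured pair covers this change, so the direction and size of the step are judged from the two values above alone, and the expectation is held loosely. The step is expected to go toward a higher number, a 2.5-fold higher number from compound 2 to compound 3 (0.40 log units; beyond the scatter), in this assay. Compound 3 is accordingly estimated at 35 nM, with a range from 10 nM to 120 nM.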

Compound 3, inhibition constant: 25 nM
The estimate for compound 3 lay 1.4-fold (0.15 log units) above the measured number; the range from low to high includes it.
By their numbers in this assay, from the lowest: compound 1; then compounds 2 and 3 (each within the scatter of the next).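

Methoxy in place of nitro on an aromatic carbon gives a 1.8-fold higher number from compound 2 to compound 3 (0.25 log units; within the scatter) in this assay, so at this position, ortho to a large group and meta to a methyl group, the numbers for the two groups cannot be told apart. For the compounds shown here, the pair also gives the first reading of how far the counted differences matter here: nitro has 3 heavy atoms and 2 hydrogen-bond acceptors, methoxy has 2 heavy atoms and 1 hydrogen-bond acceptor, neither has a net charge, and on this one pair those differences do not separate the numbers. No measurement of any property of these groups accompanies the pair, so the closeness of the two numbers remains without an explanation.

Compound 1 differs from compound 2 in two places, and the compounds shown do not divide its number between the chloro group on this carbon and the trifluoromethyl group in place of the methyl group. From the compounds shown here alone, whether an amine, a hydroxyl group or a longer ether chain such as ethoxy on the same carbon would stay within the scatter of these two numbers also remains open.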